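Replacing the ester side chain on compound 2

The source may report more compounds than this note shows. Statements on the series, on what has been measured and on what is new or still open speak of the compounds shown alone.

Compound 1 `CN1CCCN(c2nc(-c3ccccc3)nc3ccccc23)CC1`: 26.1 ug/mL
Compound 2 `COC(=O)CNc1nc(-c2ccccc2)nc2ccccc12`: 35.5 ug/mL

In a functional assay on SK-OV-3 cells (Homo sapiens) for cytotoxicity, read by sulforhodamine B assay (on this read-out lower numbers stand for stronger inhibition and higher numbers for weaker inhibition), compound 2 gives 35.5 ug/mL, which cannot be separated from compound 1 at 26.1 ug/mL. The next compound, compound 3 `CC(C)Nc1nc(-c2ccccc2)nc2ccccc12`, carries isopropyl in place of (methoxycarbonyl)methyl on a nitrogen on an aromatic ring. Going by the values given here, only one measured step bears on this change: a 1.4-fold higher number from compound 1 to compound 2 (0.13 log units; within the scatter). It exchanged 4-methyl-1,4-diazepan-1-yl for ((methoxycarbonyl)methyl)amino on an aromatic carbon and stayed within the scatter. Among the compounds with values here, no measured compound yet carries an isopropyl group, so this single step is thin evidence and the range must stay wide. No clear shift in either direction is expected in this assay, and the expected step of a 1.3-fold lower number from compound 2 to compound 3 (0.10 log units; within the scatter) is estimated to stay within the scatter. For compound 3 the expected value is 28 ug/mL, with an estimated range from 11 ug/mL to 70 ug/mL.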

Compound 3, half-maximal inhibitory concentration: 16.9 ug/mL
Compound 3: the middle estimate sits 1.7-fold (0.22 log units) above what was measured; low and high end bracket the measured number.
By their numbers in this assay, from the lowest: compounds 3, 1 and 2 (each within the scatter of the next, the first and the last beyond it).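

Going by these compounds alone, on the nitrogen on an aromatic ring, isopropyl in place of (methoxycarbonyl)methyl gives the first step in this assay that passes beyond the scatter (a 2.1-fold lower number from compound 2 to compound 3 (0.32 log units; beyond the scatter)). The comparison at the aromatic carbon reads differently, as isopropylamino and 4-methyl-1,4-diazepan-1-yl cannot be told apart (a 1.5-fold lower number from compound 1 to compound 3 (0.19 log units; within the scatter)). So the ester side chain and the isopropyl group can be separated at this nitrogen, though the step is modest, and nothing available accounts for the shift.

From the compounds shown here alone, it remains open whether the shift follows the loss of the methyl ester or the presence of the branched isopropyl group. A straight propyl chain, a longer alkyl chain, a carboxylic acid or a primary amide on the same nitrogen would bear on that question.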